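A few compounds are considered here, and "the series" means these few. Any claim that something is new, unique, unknown or untested is made for them only; others in the source may bear on it.

In a functional assay on A549 cells (Homo sapiens) for inhibition, read by MTT assay, with a stated time of 72 h (on this read-out higher numbers stand for weaker inhibition and lower numbers for stronger inhibition), compound 1 (`C/C=C\C(=O)Nc1cc(Nc2nc3c(c(-c4cn(C)c5ccc(F)cc45)n2)CS(=O)(=O)CC3)c(OC)cc1N(C)CCN(C)C`) gives 3990 nM and compound 2 (`CC/C=C\C(=O)Nc1cc(Nc2nc3c(c(-c4cn(C)c5ccc(F)cc45)n2)CS(=O)(=O)CC3)c(OC)cc1N(C)CCN(C)C`) gives 5830 nM. Within the data shown here, these two values lie within the scatter of each other, so compound 2 cannot be separated from the only other compound measured so far. Compound 3 (`COc1cc(N(C)CCN(C)C)c(NC(=O)/C=C\C(C)C)cc1Nc1nc2c(c(-c3cn(C)c4ccc(F)cc34)n1)CS(=O)(=O)CC2`) has not yet been measured. It differs from compound 2 by methyl in place of hydrogen on a saturated chain carbon bound to a double-bonded chain carbon and a saturated chain carbon, which turns the ethyl into an isopropyl at the end of the chain. Among the measured compounds shown here, the one measured step that bears on this change also puts methyl in place of hydrogen on a saturated chain carbon bound to a double-bonded chain carbon. That step is a 1.5-fold higher number from compound 1 to compound 2 (0.16 log units; within the scatter), and it stays within the scatter. A single step is thin evidence, but on the strength of it no change beyond the scatter is expected in this assay, and any drift would be expected to be small. The expected step is a 1.1-fold higher number from compound 2 to compound 3 (0.05 log units; within the scatter). For compound 3 the estimated value is 6500 nM, with an expected range from 3000 nM to 14000 nM.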

Compound 3, half-maximal inhibitory concentration: 3750 nM
Compound 3: middle estimate off by 1.7-fold (0.24 log units), on the high side, within the range that was stated.
By their numbers in this assay, from the lowest: compounds 3, 1 and 2 (each within the scatter of the next).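

In this assay, among these compounds, the methyl that turns the ethyl into an isopropyl gives a 1.6-fold lower number from compound 2 to compound 3 (0.19 log units; within the scatter), so this second added methyl, like the first, produces no step that can be separated from the scatter. The comparison with the shortest chain gives a 1.1-fold lower number from compound 1 to compound 3 (0.03 log units; within the scatter), which shows that even the whole change from methyl to isopropyl on a double-bonded chain carbon bound to a double-bonded chain carbon leaves the two compounds indistinguishable, and the series of methyl, ethyl and isopropyl ends shows no trend in either direction. Nothing available here accounts for the three compounds reading alike.

From the compounds shown here alone, all three compounds carry a small saturated hydrocarbon group at this end of the chain, so it remains open whether a tert-butyl, a cyclopropyl, a longer chain or an amine such as a dimethylamino group would move the number beyond the scatter. Going by these compounds, it is also open whether a hydrogen in place of the methyl of compound 1 would leave the number within the scatter.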